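Benzyloxy to isopentyloxy: a step from a limit

The compounds below may be only part of what the source reports. "The series", "measured", "known", "first", "only" and "open" are said of these compounds alone.

Compound 1 `O=C(/C=C/c1ccc(O)cc1)c1c(O)cccc1OCc1ccccc1` carries a benzyloxy group on the shared core. In a functional assay on ACHN cells (Homo sapiens) for antiproliferative activity, read by sulforhodamine B assay (on this read-out lower numbers stand for stronger inhibition of growth and higher numbers for weaker inhibition of growth), compound 1 gives > 30000 nM, which is a limit of the assay and not a number. Compound 3 `CC(C)(C)CCOc1cccc(O)c1C(=O)CCc1ccc(O)cc1` likewise returns only a limit in this assay, > 30000 nM. Compound 2 `CC(C)(C)CCOc1cccc(O)c1C(=O)/C=C/c1ccc(C(=O)O)cc1` gives 8450 nM in this assay. Compound 1 thus stands among the values shown without a measured number of its own; the only number shown belongs to compound 2, which differs from compound 1 in more than one place, so no single step between measured compounds is on record. The point of reference for what follows is the limit of > 30000 nM in this assay, at which 2 of the 3 values shown sit.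

Compound 4 `CC(C)CCOc1cccc(O)c1C(=O)/C=C/c1ccc(O)cc1` is the next compound. The change from compound 1 is isobutyl in place of phenyl on a saturated chain carbon bound to an oxygen on an aromatic ring. Among the measured compounds shown here, no measured step matches this change; compound 3 shows that an alkoxy chain of similar kind, with a saturated linker, also ends at the limit. The expectation is therefore a step in this assay of no size beyond the scatter, with compound 4 likely to return a limit once more. Compound 4 is estimated at 30000 nM, with a range from 10000 nM to 90000 nM. The step from compound 1 to compound 4 is expected to be a number no higher from compound 1 to compound 4 (the limit leaves the size open).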

Compound 4, concentration for 50% growth inhibition: 11300 nM
Compound 4: the middle estimate sits 2.7-fold (0.42 log units) above what was measured; the measured number falls inside the stated range.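

In this assay, among the compounds shown here, isobutyl in place of phenyl on a saturated chain carbon bound to an oxygen on an aromatic ring gives an at least 2.6-fold lower number from compound 1 to compound 4 (0.42 log units; beyond the scatter), the first step that can be read across a single place. The number at this position therefore depends on the group carried there, and the phenyl ring is not needed for a measured value, since compound 4 gives 11300 nM. Compound 1 remains at a limit of the assay and not a number, so the step has a known minimum but no known size, and that limit is shared within the series: the limit of > 30000 nM in this assay, at which 2 of the 4 values shown sit.

Going by these compounds, with a single pair of groups to read at this position, it stays open whether the lower number belongs to the isobutyl itself or to the loss of the phenyl, and a longer chain, a cyclohexyl group or an amine in the same place would be needed to separate the two. On these data alone, compound 2 and compound 3 each differ from compound 4 in more than one place, so the part played by the rest of the molecule also stays open.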